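Aminocarbamoyl Replaced by Benzyl(methyl)amino on a Shared Core

The source may hold more compounds than are shown below. What is called first, only, known or untested is meant among the compounds shown, and "the series" means these compounds.

compound 1 `NNC(=O)Cc1cc(=O)oc2cc(OCc3cccc(Cl)c3)ccc12`: 2500 nM
compound 2 `NC(=O)Cc1cc(=O)oc2cc(OCc3cccc(F)c3)ccc12`: 70000 nM

In an assay (strain Wistar) for inhibition of Amine oxidase [flavin-containing] A (Rattus norvegicus) (a lower number here means a stronger inhibitor, a higher number a weaker inhibitor), compound 1 gives the lower of the two numbers, and compound 2 returns a higher number that lies beyond the usual scatter. The two measured compounds differ in more than one place, so no single step can be read from them. Compound 3 `CN(Cc1ccccc1)Cc1cc(=O)oc2cc(OCc3cccc(Cl)c3)ccc12` is not yet measured; it differs from compound 1 by benzyl(methyl)amino in place of aminocarbamoyl on a saturated chain carbon bound to an aromatic carbon. Without a measured step resembling this change, a moderate loss in this assay is anticipated rather than established. Compound 3 is estimated at 10000 nM, within 2000 nM to 50000 nM. The expected change is a 4.0-fold higher number from compound 1 to compound 3 (0.60 log units; beyond the scatter).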

Compound 3, half-maximal inhibitory concentration: > 100000 nM
Compound 3 was reported as a limit; the forecaster's own chance of this, stated with the estimate: 15%; middle value at least 10-fold (1.00 log units) away from the limit.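

In this assay, the saturated chain carbon bound to an aromatic carbon proves sensitive to substitution: on the shared core, benzyl(methyl)amino in place of aminocarbamoyl gives an at least 40-fold higher number from compound 1 to compound 3 (1.60 log units; beyond the scatter). Within the data shown here, this is the first single change that can be read, as compound 1 and compound 2 differ in more than one place. The value of compound 3 is a limit of the assay, not a number: the limit of > 100000 nM in this assay, at which 1 of the 3 values shown sits.

The compounds shown leave open whether the benzyl or the methylamino part accounts for the loss. A smaller dimethylamino group, a primary amine or a carboxylic acid at this place could separate these possibilities.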